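Hydroxy in place of methyl: compound 4 awaits its number

A few compounds are considered here, and "the series" means these few. Any claim that something is new, unique, unknown or untested is made for them only; others in the source may bear on it.

Compound 1 `O=C(O)[C@H]1CC[C@](F)(C(=O)N2CC[C@](c3ccc(C(F)(C(F)(F)F)C(F)(F)F)cc3)(S(=O)(=O)c3ccc(F)cc3)C2)CC1`, compound 2 `O=C(O)C12CCC(C(=O)N3CC[C@](c4ccc(C(F)(C(F)(F)F)C(F)(F)F)cc4)(S(=O)(=O)c4ccc(F)cc4)C3)(CC1)CC2` and compound 3 `CC1(C(=O)N2CC[C@](c3ccc(C(F)(C(F)(F)F)C(F)(F)F)cc3)(S(=O)(=O)c3ccc(F)cc3)C2)CCS(=O)(=O)CC1` share a core and differ in the group on its carbonyl. In an ADME assay on microsomes from liver (Mus musculus) for metabolic stability, with a stated time of 10 min (on this read-out lower numbers stand for a less stable compound and higher numbers for a more stable compound), compound 2 stands at 73% and is the only one of the three with a number. Compound 1 is entered as "not determined" (no result reported) and so offers nothing to compare. Compound 3 is entered as "not determined" (no result reported) and therefore has no position on the scale.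

Compound 4 `O=C(N1CC[C@](c2ccc(C(F)(C(F)(F)F)C(F)(F)F)cc2)(S(=O)(=O)c2ccc(F)cc2)C1)C1(O)CCS(=O)(=O)CC1` has hydroxy in place of methyl on a saturated ring carbon at a place three ring bonds from the ring sulfur. The same difference reads 4-methyl-1,1-dioxothian-4-yl to 4-hydroxy-1,1-dioxothian-4-yl.

Going by the values given here, no measured pair here differs in one place, so nothing shows what this swap does in this assay and no step beyond the usual scatter is expected in either direction. With no number for compound 3, the expectation leans on compound 2 at 73% as the sole anchor, although it carries a different group on the carbonyl. For compound 4 the estimated value is 72% with an expected range from 50% to 90% in this read-out.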

Compound 4, percent of the compound remaining: 90%
Compound 4: middle estimate off by 18 percentage points, on the low side, and the stated range covers the measured number.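

In this assay, the group on the carbonyl now has a second reading, and the exchange of the group of compound 2 for 4-hydroxy-1,1-dioxothian-4-yl gives a number 17 percentage points higher from compound 2 to compound 4 (beyond the scatter), the first sign among these compounds that the read-out responds to a change at this position. That step replaces a whole group, so it does not isolate the hydroxy, and the direct step from methyl to hydroxy, along with any other step involving compound 1 or compound 3, cannot be read without a number for those compounds. No measurement is available here that would explain the higher number for compound 4.

It remains open whether the hydroxy on the saturated ring carbon, three ring bonds from the ring sulfur, or the sulfur-containing ring as a whole accounts for the step, since the compounds shown do not separate the two. Also open, from the compounds shown here alone, is what an amine, a methoxy group or a carboxylic acid at that same ring carbon would give in this assay, with the rest of compound 4 left unchanged.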